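Bombesin receptor subtype-3 series: carboxypyridinyl replacement for thiazolyl

The compounds below may be only part of what the source reports. "The series", "measured", "known", "first", "only" and "open" are said of these compounds alone.

Of the compounds shown here, three of the shared core have been measured in a functional assay on HEK293 cells for agonist activity at Bombesin receptor subtype-3 (Homo sapiens), read by luminescence and calcium flux, with a stated time of 10 min; a lower number here means that less compound is needed, a higher number that more compound is needed for the effect. Compound 1 `CCC(C)(C)Cc1c[nH]c(CCc2ccc(-n3cccn3)cc2)n1` gives 106 nM. Compound 2 `CCC(C)(C)Cc1c[nH]c(CCc2ccc(-c3ccc(F)cn3)cc2)n1` gives 97 nM. Compound 3 `CCC(C)(C)Cc1c[nH]c(CCc2ccc(-c3cnsc3)cc2)n1` gives 100 nM. All three numbers lie together: a 1.1-fold lower number from compound 1 to compound 3 (0.03 log units; within the scatter), and a 1.0-fold higher number from compound 2 to compound 3 (0.01 log units; within the scatter); likewise a 1.1-fold lower number from compound 1 to compound 2 (0.04 log units; within the scatter). On these numbers compound 3 sits with the other two, none separated beyond the scatter.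

Compound 4 `CCC(C)(C)Cc1c[nH]c(CCc2ccc(-c3cccnc3C(=O)O)cc2)n1` remains to be measured in this assay. The change from compound 3 is 2-carboxypyridin-3-yl in place of 1,2-thiazol-4-yl on an aromatic carbon. The measured steps that bear on it are the three exchanges of the aromatic group at the same position, each within the scatter, so swapping one small aromatic ring for another has so far left the number unchanged. Within the data shown here, the entering group here, however, carries a carboxylic acid, a feature no measured compound holds, so the earlier steps give only a weak guide. A step beyond the scatter toward a higher number is therefore allowed for but not expected with confidence; the expected step is a 2.2-fold higher number from compound 3 to compound 4 (0.34 log units; beyond the scatter). Compound 4 is estimated at 220 nM, with a range from 60 nM to 1200 nM.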

Compound 4, half-maximal effective concentration: 95 nM
Beside the measured number, compound 4's estimate is 2.3-fold (0.36 log units) above it; low and high end bracket the measured number.
By their numbers in this assay, from the lowest: compounds 4, 2, 3 and 1 (each within the scatter of the next).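

The 2-carboxypyridin-3-yl group brings a carboxylic acid to this position, and in this assay the number still does not separate from those of the earlier aromatic groups (the steps are a 1.1-fold lower number from compound 3 to compound 4 (0.02 log units; within the scatter) and a 1.0-fold lower number from compound 2 to compound 4 (0.01 log units; within the scatter) and a 1.1-fold lower number from compound 1 to compound 4 (0.05 log units; within the scatter)). On the six-membered aromatic ring of carbon only, para to a large group, a substituent with a hydrogen-bond donor and a double bond outside aromatic rings therefore gives no step beyond the scatter, which the earlier groups, without these features, could not show. No supporting data bear on why the number holds across these groups.

All four groups shown are aromatic rings, so an amine, a longer alkyl chain or a simple amide at this position remain open. From the compounds shown here alone, no group at this position yet separates from the others, and whether the carboxylic acid is accepted equally with other changes to the shared core is also open.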